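Benzyl Group Exchange in an Antiproliferative Series

A few compounds are considered here, and "the series" means these few. Any claim that something is new, unique, unknown or untested is made for them only; others in the source may bear on it.

Compound 1 `Cc1ccccc1CN1CCc2c(sc(NC(=O)c3ccccc3Cl)c2C(N)=O)C1` in a functional assay on HeLa cells (Homo sapiens) for antiproliferative activity, with a stated time of 24 h (on this read-out higher numbers stand for weaker inhibition and lower numbers for stronger inhibition), gives > 50000 nM, which is a limit of the assay.
Compound 2 `N#Cc1ccccc1CN1CCc2c(sc(NC(=O)c3ccccc3Cl)c2C(N)=O)C1` gives in this assay > 50000 nM, again only a limit.
Compound 3 `NC(=O)c1c(NC(=O)c2ccccc2Cl)sc2c1CCN(Cc1ccccc1F)C2` gives in this assay > 50000 nM, also a limit.

The three measured compounds share one core and differ only in the group on the benzyl ring. Every value recorded for them sits at the same limit, as the limit of > 50000 nM in this assay, at which 3 of the 3 values shown sit, states. The steps a step that the two limits leave unreadable from compound 1 to compound 2, a step that the two limits leave unreadable from compound 1 to compound 3 and a step that the two limits leave unreadable from compound 2 to compound 3 are therefore all unreadable in size, and compound 3 cannot be placed above or below the other two; it simply stands at the limit with them.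

Compound 4 `NC(=O)c1c(NC(=O)c2ccccc2Cl)sc2c1CCN(Cc1ccc([N+](=O)[O-])cc1)C2` carries the change (4-nitrophenyl in place of 2-fluorophenyl on a saturated chain carbon bound to an amine nitrogen in a ring). Among the measured compounds shown here, no measured step bears on this exchange in a readable way, since every step among compounds 1, 2 and 3 is hidden by the limit. The expectation for compound 4 can rest only on the fact that all three known benzyl variants show no measurable inhibition. The step from compound 3 to compound 4 is therefore estimated as a step that the limit leaves unreadable from compound 3 to compound 4, meaning no change beyond the scatter. Compound 4 is expected to give about 100000 nM, between 30000 nM and 500000 nM, most probably again reported only as a limit.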

Compound 4, half-maximal inhibitory concentration: 46100 nM
For compound 4 the middle estimate is 2.2-fold (0.34 log units) above the measured one; measured number inside the range.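

In this assay compound 4 gives 46100 nM, so the group on this saturated chain carbon bound to an amine nitrogen in a ring now has a number in the series. Set against the three earlier benzyl variants, the exchange reads as an at least 1.0-fold lower number from compound 3 to compound 4 (0.03 log units; that floor lies within the scatter), as an at least 1.0-fold lower number from compound 2 to compound 4 (0.03 log units; that floor lies within the scatter) and as an at least 1.0-fold lower number from compound 1 to compound 4 (0.03 log units; that floor lies within the scatter), so each step gives only a floor and none shows a change beyond the scatter. Compound 4 is the only compound shown that is not reported at a limit, while the other three remain there: the limit of > 50000 nM in this assay, at which 3 of the 4 values shown sit.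

The name of the entering group changes in two ways at once, from 2-fluorophenyl, 2-cyanophenyl or 2-methylphenyl to 4-nitrophenyl, so the compounds shown do not separate the nitro group from the 4 in its name. Going by these compounds, a 2-nitrophenyl or a 4-fluorophenyl group would bear on that question, and whether a 4-aminophenyl or a 4-carboxyphenyl group would give a readable number in this assay also remains open.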